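From Benzyl to 3-Bromo-4-methoxybenzyl: What Might Change?

This account rests on a few compounds, and the source may have more. Where it says the series, first, only, none or still open, it means among the compounds named here.

- compound 1 `COc1ccc(CN(C(=O)CSc2nc3ccccc3s2)c2cc(OC)c(OC)c(OC)c2)cc1C`: 17100 nM
- compound 2 `COc1ccc(CN(C(=O)CSc2nc3ccccc3s2)c2cc(OC)c(OC)c(OC)c2)cc1`: 426 nM
- compound 3 `COc1cc(N(Cc2ccccc2)C(=O)CSc2nc3ccccc3s2)cc(OC)c1OC`: 54500 nM

In a functional assay on HCT-116 cells (Homo sapiens) for antiproliferative activity, read by MTT assay, with a stated time of 48 h (on this read-out higher numbers stand for weaker inhibition and lower numbers for stronger inhibition), compound 3 gives 54500 nM, the highest of the three numbers, which makes it the weakest inhibitor of the set. The next compound to consider is compound 4 `COc1ccc(CN(C(=O)CSc2nc3ccccc3s2)c2cc(OC)c(OC)c(OC)c2)cc1Br`, and it differs from compound 3 as follows: 3-bromo-4-methoxyphenyl in place of phenyl on a saturated chain carbon bound to an amide-type nitrogen. In words, 3-bromo-4-methoxyphenyl stands in place of phenyl on a saturated chain carbon bound to an amide-type nitrogen.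

Two measured steps end at compound 3 and bear on this change. One is a 130-fold higher number from compound 2 to compound 3 (2.11 log units; beyond the scatter), a large step in which hydrogen replaces methoxy. The other is a 3.2-fold higher number from compound 1 to compound 3 (0.50 log units; beyond the scatter), a modest step in which phenyl replaces 4-methoxy-3-methylphenyl. Both show a higher number for the plain phenyl group. However, a 40-fold lower number from compound 1 to compound 2 (1.60 log units; beyond the scatter) is also large, so a further group on the ring can matter greatly in this assay. For the measured compounds named here, no measured compound carries bromine, which leaves the size uncertain. The expected change is a 9.1-fold lower number from compound 3 to compound 4 (0.96 log units; beyond the scatter), a step towards stronger inhibition. For compound 4 the estimated value is 6000 nM, with an expected range from 800 nM to 35000 nM.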

Compound 4, half-maximal inhibitory concentration: 4550 nM
Compound 4: the middle estimate sits 1.3-fold (0.12 log units) above what was measured; low and high end bracket the measured number.
By their numbers in this assay, from the lowest: compound 2; then compound 4; then compound 1; then compound 3.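

The 3-bromo-4-methoxybenzyl group gives a clear gain over plain benzyl in this assay, with a 12-fold lower number from compound 3 to compound 4 (1.08 log units; beyond the scatter) on a saturated chain carbon bound to an amide-type nitrogen. The earlier compounds shown here showed that a methyl group on the methoxy-bearing ring goes with a much higher number than hydrogen, and bromo now gives a third point at that same ring place: it stands worse than hydrogen, with an 11-fold higher number from compound 2 to compound 4 (1.03 log units; beyond the scatter), yet better than methyl, with a 3.8-fold lower number from compound 1 to compound 4 (0.57 log units; beyond the scatter). Among these three compounds, the numbers therefore rise from hydrogen to bromo to methyl, so bromo does not improve on the methoxybenzyl group of compound 2, which keeps the lowest number of the set.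

Nothing measured on these compounds explains this order. Going by these compounds, it also remains open where a fluoro, a chloro, an amino group or a carboxylic acid at this ring place would fall relative to hydrogen, bromo and methyl.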